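The source may report more compounds than this note shows. Statements on the series, on what has been measured and on what is new or still open speak of the compounds shown alone.

Of the compounds shown here, three built on one shared core have been measured in a functional assay (Oryctolagus cuniculus) for inhibition of platelet-activating factor receptor (Cavia porcellus); a lower number here means a stronger inhibitor, a higher number a weaker inhibitor. Compound 1 `CCCC(=O)OCC1CN(C(=O)c2cc(OC)c(OC)c(OC)c2)CCN1C(=O)c1cc(OC)c(OC)c(OC)c1` gives 420 nM, compound 2 `CCCCCCCC(=O)OCC1CN(C(=O)c2cc(OC)c(OC)c(OC)c2)CCN1C(=O)c1cc(OC)c(OC)c(OC)c1` gives 310 nM, and compound 3 `COc1cc(C(=O)N2CCN(C(=O)c3cc(OC)c(OC)c(OC)c3)C(COC(=O)NC(C)(C)C)C2)cc(OC)c1OC` gives 130 nM. Compound 3 thus stands at the lowest number of the three. Its nearest neighbour is compound 2, and the step of a 2.4-fold lower number from compound 2 to compound 3 (0.38 log units; beyond the scatter) lies beyond the scatter, as does the step of a 3.2-fold lower number from compound 1 to compound 3 (0.51 log units; beyond the scatter). The step of a 1.4-fold lower number from compound 1 to compound 2 (0.13 log units; within the scatter) lies within the scatter.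

Compound 4 `CCCN(CCC)C(=O)OCC1CN(C(=O)c2cc(OC)c(OC)c(OC)c2)CCN1C(=O)c1cc(OC)c(OC)c(OC)c1` differs from compound 3 in one place: dipropylamino in place of (tert-butyl)amino on a carbonyl carbon. Among the measured compounds shown here, no measured pair involves the exchange of one amino group for another on this carbonyl carbon. The steps that come closest are a 3.2-fold lower number from compound 1 to compound 3 (0.51 log units; beyond the scatter) and a 2.4-fold lower number from compound 2 to compound 3 (0.38 log units; beyond the scatter), both of which put the (tert-butyl)amino group on the carbonyl carbon in place of a chain and brought modest gains. None of these steps tells whether dipropylamino will match (tert-butyl)amino, and the entering group carries no hydrogen-bond donor where the leaving one carried one. Compound 4 is therefore expected to land near compound 3. The estimated step of a 1.5-fold higher number from compound 3 to compound 4 (0.19 log units; within the scatter) is expected to stay inside the scatter, with a wide range around it. For compound 4 the estimate in this assay is 200 nM, between 70 nM and 600 nM.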

Compound 4, half-maximal inhibitory concentration: 380 nM
For compound 4 the middle estimate is 1.9-fold (0.28 log units) below the measured one, and the stated range covers the measured number.
By their numbers in this assay, from the lowest: compound 3; then compounds 2, 4 and 1 (each within the scatter of the next).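

In this assay, among the compounds shown here, the step of a 2.9-fold higher number from compound 3 to compound 4 (0.47 log units; beyond the scatter) is the only exchange of one amino group for another on this carbonyl carbon, and it shows that the gain seen with (tert-butyl)amino does not extend to every amino group placed there. Dipropylamino instead leaves compound 4 level with the compounds carrying plain chains: the steps of a 1.2-fold higher number from compound 2 to compound 4 (0.09 log units; within the scatter) and a 1.1-fold lower number from compound 1 to compound 4 (0.04 log units; within the scatter) both stay within the scatter, so a nitrogen on this carbonyl carbon does not by itself set a compound apart from those chains. Of the four compounds, compound 3 alone carries a hydrogen-bond donor in this group, and it alone stands apart from the others, but no evidence at hand accounts for this.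

The compounds shown leave open whether the amide hydrogen or the tert-butyl group sets compound 3 apart, a question that propylamino, or tert-butyl itself, on this carbonyl carbon would address. They also leave open whether a smaller group such as dimethylamino would behave like dipropylamino.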